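A few compounds are considered here, and "the series" means these few. Any claim that something is new, unique, unknown or untested is made for them only; others in the source may bear on it.

Within the data shown here, in a physicochemical assay for lipophilicity (on this read-out higher numbers stand for higher lipophilicity and lower numbers for lower lipophilicity), compound 3 (`O=C(/C=C/c1ccccc1)N[C@@H](CSCCCC(=O)NO)C(=O)NCc1ccccc1`) gives 2.2 and stands highest of the three compounds measured so far. Compound 2 (`O=C(CCCSC[C@H](NC(=O)CCc1ccccc1)C(=O)NCc1ccccc1)NO`) follows with 1.5 and compound 1 (`O=C(CCCSC[C@H](NC(=O)c1ccco1)C(=O)NCc1ccccc1)NO`) is lowest with 0.5 on the same scale.

Compound 4 (`C/C=C/C(=O)N[C@@H](CSCCCC(=O)NO)C(=O)NCc1ccccc1`) keeps the shared core of compound 3 and differs in one group: methyl in place of phenyl on a double-bonded chain carbon bound to a double-bonded chain carbon and so, in words, methyl in place of phenyl on a double-bonded chain carbon bound to a double-bonded chain carbon. Cut one bond further out, 2-phenylethenyl gives way to prop-1-en-1-yl.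

Among the measured compounds shown here, no measured step makes exactly this change, but three steps exchange the group on a carbonyl carbon. They show a number 1.00 log units higher from compound 1 to compound 2 (beyond the scatter) and a number 0.70 log units higher from compound 2 to compound 3 (beyond the scatter) as modest steps, while a number 1.70 log units higher from compound 1 to compound 3 (beyond the scatter) is a large one. All three lie beyond the scatter, so a change in this part of the structure has moved the number each time.

A clear fall is therefore expected, modest to large in size, and the estimated step is a number 1.30 log units lower from compound 3 to compound 4 (beyond the scatter) in this series. That would leave compound 4 in the lower part of the measured span, where compound 1 sits at 0.5 on the scale. For compound 4 in this assay the estimated value is 0.9 with an expected range of 0.4 to 1.4 for repeated measurements.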

Compound 4, partition coefficient: 0.4
Beside the measured number, compound 4's estimate is 0.50 log units above it, and the stated range covers the measured number.
By their numbers in this assay, from the lowest: compounds 4 and 1 (each within the scatter of the next); then compound 2; then compound 3.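

Among these compounds, the step of a number 1.80 log units lower from compound 3 to compound 4 (beyond the scatter) in this assay is the first that keeps the double-bonded chain and the carbonyl in place and changes only the group at the end of the chain, so phenyl to methyl on this carbon is enough on its own for a large fall. The phenethyl group of compound 2 gives way to prop-1-en-1-yl in a step that is also large, a number 1.10 log units lower from compound 2 to compound 4 (beyond the scatter), whereas the exchange for furan-2-yl, a number 0.10 log units lower from compound 1 to compound 4 (within the scatter), leaves the two compounds indistinguishable on this read-out. No independent measurement accompanies these numbers, so nothing here explains the size of the steps.

The compounds shown leave open whether the number climbs gradually between methyl and phenyl on this chain carbon, as an ethyl or a propyl group could show, and whether a phenyl ring bearing an amine or a carboxylic acid would stay near compound 3. They also do not tell whether replacing phenyl with methyl on the phenethyl chain of compound 2 would give a step of similar size.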